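The compounds below may be only part of what the source reports. "The series", "measured", "known", "first", "only" and "open" are said of these compounds alone.

Compound 2, `CC(C)(C)NC(=O)N1CC1C#N`, carries a tert-butyl group on an amide-type nitrogen. In a functional assay on WiDr cells (Homo sapiens) for inhibition (a higher number here means a weaker inhibitor, a lower number a stronger inhibitor), compound 2 reaches only a limit, > 300000 nM, and no number. Its nearest measured relative is compound 1, `CCCCNC(=O)N1CC1C#N`, which carries a butyl group in the same place; in this assay compound 1 gives 18000 nM. Within the data shown here, the step of an at least 16-fold higher number from compound 1 to compound 2 (1.22 log units; beyond the scatter) is the only measured step that bears on the change considered here, and its true size is unknown, as compound 2 sits at the limit of > 300000 nM in this assay, at which 1 of the 3 values shown sits. A third compound, compound 3, `N#CC1CN1C(=O)Nc1ccc(Cl)cc1Cl`, gives 1900 nM in this assay. Compound 4, `CCNC(=O)N1CC1C#N`, is not yet measured; it differs from compound 2 by ethyl in place of tert-butyl on an amide-type nitrogen. Returning from the tert-butyl group to a straight chain is expected to bring the number back toward what compound 1 shows with 18000 nM, so the step of an at least 10-fold lower number from compound 2 to compound 4 (1.00 log units; beyond the scatter) is expected to be a large fall. For compound 4 the estimate in this assay is 30000 nM, within a range from 8000 nM to 150000 nM.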

Compound 4, half-maximal inhibitory concentration: 7000 nM
Compound 4: middle estimate off by 4.3-fold (0.63 log units), on the high side, and the stated range ends above it.
By their numbers in this assay, from the lowest: compound 3; then compound 4; then compound 1. At a limit, above all of these: compound 2.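

The step of an at least 42-fold lower number from compound 2 to compound 4 (1.63 log units; beyond the scatter) shows that in this assay the near-total loss seen with compound 2 goes with its tert-butyl group and not with the shared core, as ethyl on the same amide-type nitrogen gives a measurable inhibitor. The step of a 2.6-fold lower number from compound 1 to compound 4 (0.41 log units; beyond the scatter) adds that, of the two straight chains, the shorter ethyl gives the stronger inhibitor, so a long chain is not needed here. From the compounds shown here alone, compound 2 stands at a limit and not at a number, so the true size of the first step remains unknown: the limit of > 300000 nM in this assay, at which 1 of the 4 values shown sits.

Still open, going by these compounds, is whether a methyl group or a plain amide hydrogen on this nitrogen would lower the number further, and where a branched isopropyl group would fall. Also open, on these data alone, is whether a plain phenyl group would come close to compound 3, which gives 1900 nM in this series.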